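The source may report more compounds than this note shows. Statements on the series, on what has been measured and on what is new or still open speak of the compounds shown alone.

Values in a functional assay on HOS cells (Homo sapiens) for antiproliferative activity, read by sulforhodamine B assay; a higher number here means a weaker inhibitor of growth, a lower number a stronger inhibitor of growth:
Compound 1 `CC(=O)O[C@@H]1[C@@H](OCc2ccccc2)[C@H](OCc2ccccc2)[C@@H](COCc2ccccc2)O[C@H]1C` gives 8800 nM.
Compound 2 `CC[C@@H]1O[C@H](COCc2ccccc2)[C@@H](OCc2ccccc2)[C@H](OCc2ccccc2)[C@H]1OC(C)=O` gives only a limit of the assay, > 50000 nM.
Compound 3 `CCC[C@@H]1O[C@H](COCc2ccccc2)[C@@H](OCc2ccccc2)[C@H](OCc2ccccc2)[C@H]1O` gives 38600 nM.

Compound 3 and compound 1 differ in more than one place; the difference between the two cores is not broken down here. Of the two numbers, compound 3 stands highest, with compound 1 nearest below it. From compound 1 to compound 2 the change is methyl in place of hydrogen on a saturated chain carbon bound to a saturated ring carbon, and it made an at least 5.6-fold higher number from compound 1 to compound 2 (0.75 log units; beyond the scatter); since compound 2 sits at the limit of > 50000 nM in this assay, at which 1 of the 3 values shown sits, only a least size of that step is known.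

Compound 4 `CCCC[C@@H]1O[C@H](COCc2ccccc2)[C@@H](OCc2ccccc2)[C@H](OCc2ccccc2)[C@H]1O` is not yet measured in this assay. It differs from compound 3 by methyl in place of hydrogen on a saturated chain carbon, three bonds along the chain from a saturated ring carbon. This is the same kind of change as from compound 1 to compound 2, not the same: there the methyl enters on a saturated chain carbon bound to a saturated ring carbon, here on a saturated chain carbon three bonds along the chain from a saturated ring carbon. Resting on an at least 5.6-fold higher number from compound 1 to compound 2 (0.75 log units; beyond the scatter), a weakening of growth inhibition is expected, with an expected step of a 1.7-fold higher number from compound 3 to compound 4 (0.23 log units; within the scatter). Compound 4 is expected near 65000 nM, within 25000 nM to 160000 nM, and may well give only a limit.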

Compound 4, concentration for 50% growth inhibition: 40100 nM
Beside the measured number, compound 4's estimate is 1.6-fold (0.21 log units) above it; measured number inside the range.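

On the core of compound 3, methyl in place of hydrogen on a saturated chain carbon, three bonds along the chain from a saturated ring carbon, gave a 1.0-fold higher number from compound 3 to compound 4 (0.02 log units; within the scatter) in this assay. The size of the earlier step did not carry over to this core, and the gap between the two steps lies beyond the scatter: the same change on two cores in this assay, an at least 5.6-fold higher number (0.75 log units; beyond the scatter) from compound 1 to compound 2 and a 1.0-fold higher number (0.02 log units; within the scatter) from compound 3 to compound 4, at least 5.4-fold (0.73 log units) apart, beyond the scatter of two such steps

Compound 2 gives only a limit of the assay, > 50000 nM, and the earlier step therefore has a least size and no known full size; the methyl also enters at a different place in the two steps, and these pairs do not separate the effect of the core from that of the place.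

Still open, as far as these compounds go, is how a longer chain such as pentyl, or an amine or a carboxylic acid in place of the butyl chain, would read on the core of compound 3. Also open, from the compounds shown here alone, is whether an ethyl chain on that core would match the step seen on the core of compound 1.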